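The compounds below may be only part of what the source reports. "The series", "measured", "known", "first", "only" and "open" are said of these compounds alone.

In a physicochemical assay, with a stated time of 30 min (a higher number here means that more compound is needed for the effect, a lower number that less compound is needed), compound 1 `C/C(=N\N=C1/SCC(=O)N1Cc1cccc(F)c1)c1cccs1` gives 2550000 nM while compound 2 `C/C(=N\N=C1/SCC(=O)N1Cc1cccc(Cl)c1)c1cccs1` gives 1590000 nM and compound 3 `CC(C)=N/N=C1\SCC(=O)N1Cc1ccc(N)cc1` gives 1770000 nM as its reading. Compound 2 therefore stands within the usual scatter of both other compounds, and these numbers do not set it apart. Compound 4 `C/C(=N\N=C1/SCC(=O)N1Cc1cccc(Cl)c1)c1ccccn1` differs from compound 2 in one place, with pyridin-2-yl in place of thiophen-2-yl on a carbon with a double bond to nitrogen. Among the measured compounds shown here, the only measured step between close neighbours (a 1.6-fold lower number from compound 1 to compound 2 (0.21 log units; within the scatter)) is chloro in place of fluoro on an aromatic carbon, a change elsewhere in the structure. For the measured compounds named here, no measured step touches the thiophen-2-yl group, so the data give no direction for this replacement, and no step beyond the scatter is expected in this assay for it. For compound 4 the expected value is 1800000 nM with an estimated range from 900000 nM to 3500000 nM as the likely span. This estimate means a 1.1-fold higher number from compound 2 to compound 4 (0.05 log units; within the scatter) as the expected step.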

Compound 4, half-maximal effective concentration: 1400000 nM
Compound 4: middle estimate off by 1.3-fold (0.11 log units), on the high side; measured number inside the range.
By their numbers in this assay, from the lowest: compounds 4, 2, 3 and 1 (each within the scatter of the next).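

In this assay the carbon with a double bond to nitrogen now has its first measured replacement, pyridin-2-yl in place of thiophen-2-yl, and this gives a 1.1-fold lower number from compound 2 to compound 4 (0.06 log units; within the scatter). Moving from a five-membered to a six-membered aromatic ring, with nitrogen instead of sulfur as the hetero atom, therefore does not set compound 4 apart from compound 2 in this reading. Nothing available explains this result or bears on it.

As far as these compounds go, only these two aromatic rings can be compared at this carbon, so it remains open whether a phenyl ring, or a pyridine ring carrying an amine or a carboxylic acid, would give a step beyond the scatter. From the compounds shown here alone, it is also open whether fluoro in place of chloro on the aromatic carbon would read the same alongside pyridin-2-yl.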